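The source may hold more compounds than are shown below. What is called first, only, known or untested is meant among the compounds shown, and "the series" means these compounds.

Measured compounds:
- compound 1, `CCCCC#Cc1cc2cn([C@@H]3O[C@H](CO)[C@@H](O)[C@H]3O)c(=O)nc2o1`: in a functional assay on HEL cells (Homo sapiens) for cytotoxicity (on this read-out lower numbers stand for higher toxicity in this test and higher numbers for lower toxicity in this test), compound 1 gives > 144000 nM, which is a limit of the test and not a number.
- compound 2, `CCCCC#Cc1cc2cn([C@H]3C[C@H](O)[C@@H](CO)O3)c(=O)nc2o1`: in this assay compound 2 gives > 150000 nM, again a limit rather than a number.

Compound 1 therefore stands at the edge of what this assay can report, as the limit of > 144000 nM in this assay, at which 1 of the 2 values shown sits, shows, and compound 2 sits in the same position, as the limit of > 150000 nM in this assay, at which 1 of the 2 values shown sits, shows. Among the compounds with values here, the one measured step, a step that the two limits leave unreadable from compound 1 to compound 2, is hydrogen in place of hydroxy on a saturated ring carbon, and its size cannot be read from two limits.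

Compound 3, `CCCCCCCCC#Cc1cc2cn([C@@H]3O[C@H](CO)[C@@H](O)[C@H]3O)c(=O)nc2o1`, differs from compound 1 by butyl in place of hydrogen on a saturated chain carbon, four bonds along the chain from a triple-bonded carbon. Within the data shown here, no measured step here changes the chain, so the single step that exists does not bear on this change, and the two limits give no direction. On that basis the expectation is that compound 3 also stays near the edge of the test, with an expected step of an at least 1.2-fold lower number from compound 1 to compound 3 (0.07 log units; that floor lies within the scatter) that cannot be separated from the scatter. The estimate for compound 3 in this assay is 120000 nM, within 25000 nM to 400000 nM.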

Compound 3, minimum cytotoxic concentration: 49000 nM
The estimate for compound 3 lay 2.4-fold (0.39 log units) above the measured number; measured number inside the range.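

Butyl in place of hydrogen on a saturated chain carbon, four bonds along the chain from a triple-bonded carbon, gives an at least 2.9-fold lower number from compound 1 to compound 3 (0.46 log units; beyond the scatter), the first change in this set with a readable effect in this assay. Since a lower number stands for higher toxicity in this test, the longer chain on this position makes the compound more toxic to these cells, by a margin that the usual scatter does not account for, so this position is not silent in this test. The true size of the step could be larger, because compound 1 is known only as a limit of the test and not as a number: the limit of > 144000 nM in this assay, at which 1 of the 3 values shown sits.

As far as these compounds go, the step from compound 1 to compound 2 still cannot be read, so the effect of removing that ring hydroxy remains unknown, as does whether butyl would act in the same way on the ring of compound 2. Also open, from the compounds shown here alone, is how the number changes along the chain, for instance with a shorter addition such as ethyl, a chain longer than that of compound 3, or a chain ending in an amine or a carboxylic acid, and what in the chain causes the change.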